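The compounds below may be only part of what the source reports. "The series", "measured", "known", "first", "only" and "open" are said of these compounds alone.

Compound 1 `NC(=S)n1ccc2c(OCCCCCOc3ccc(Cl)cc3)cccc21` gives 24700 nM in an ADME assay on Huh-7 cells (Homo sapiens) for cytotoxicity; on this read-out lower numbers stand for higher toxicity in this test and higher numbers for lower toxicity in this test.
Compound 2 `O=C(NC(=S)N1CCc2cc(OCc3ccccc3)ccc21)c1ccccc1` gives 45200 nM.
Compound 3 `O=C(NC(=S)N1CCc2c(OCCCCCOc3ccc(Cl)cc3)cccc21)c1ccc(C(F)(F)F)cc1` gives 32700 nM.

These three numbers lie close together: compound 3 differs from compound 1 and from compound 2 by less than the usual scatter of repeated measurement, so no order among them can be drawn. Compound 4 `O=C(NC(=S)N1CCc2c(OCCCCCOc3ccc(Cl)cc3)cccc21)c1ccc2ccccc2c1` shares the core of compound 3 and differs from it in one place: naphthalen-2-yl in place of 4-(trifluoromethyl)phenyl on a carbonyl carbon. Among the measured compounds shown here, no measured pair shows this kind of change, so there is nothing to set its size from. The expectation is a step of a 1.3-fold lower number from compound 3 to compound 4 (0.12 log units; within the scatter) that stays within the scatter, tending if anything toward a slightly lower number. Compound 4 is therefore estimated at 25000 nM, with a range from 10000 nM to 60000 nM.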

Compound 4, half-maximal cytotoxic concentration: > 50000 nM
Compound 4 ended at the assay's limit (the forecaster's own chance of this, stated with the estimate: 10%); at least 2.0-fold (0.30 log units) between middle value and limit.
By their numbers in this assay, from the lowest: compounds 1, 3 and 2 (each within the scatter of the next). At a limit, above all of these: compound 4.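

On a carbonyl carbon, naphthalen-2-yl in place of 4-(trifluoromethyl)phenyl gives an at least 1.5-fold higher number from compound 3 to compound 4 (0.18 log units; that floor lies within the scatter). Among the compounds shown here, the reading for compound 4 in this assay is a limit and not a number: the limit of > 50000 nM in this assay, at which 1 of the 4 values shown sits. This is the first change at this position that can be read, and it points toward a higher number, although its floor alone does not separate the two compounds.

On these data alone, how far compound 4 truly lies past that limit stays open. So does what a carboxylic acid or an amine would do on this carbonyl carbon.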